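Swapping the purine substituent: isopropyl to cyclopentyl

The compounds below may be only part of what the source reports. "The series", "measured", "known", "first", "only" and "open" are said of these compounds alone.

Measured compounds:
compound 1 `CC(C)n1cnc2c(Nc3ccccc3)nc(NCOCc3ccc(C(=O)Nc4ccccc4N)cc3)nc21` gives 18.8%
compound 2 `CC(C)n1cnc2c(Nc3ccccc3)nc(NCOCc3ccc(/C=C/C(=O)Nc4ccccc4N)cc3)nc21` gives 41.7%

Both compounds were tested in a functional assay on HCT-116 cells (Homo sapiens) for antiproliferative activity, read by CCK-8 assay, with a stated time of 72 h, tested at 8 uM; a higher number here means a stronger effect of the compound at the concentration tested, a lower number a weaker effect. For the measured compounds named here, compound 1 has the lower of the two numbers; the only neighbour is compound 2, reached by a number 22.9 percentage points higher from compound 1 to compound 2 (beyond the scatter). That step changes the group on the aromatic carbon of the benzamide side, not the core.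

Compound 3 `Nc1ccccc1NC(=O)c1ccc(COCNc2nc(Nc3ccccc3)c3ncn(C4CCCC4)c3n2)cc1` is not yet measured. It differs from compound 1 at the other end of the molecule: cyclopentyl in place of isopropyl on an aromatic nitrogen. Going by the values given here, no measured step touches this position, so there is nothing to carry over directly. The only shown step, from compound 1 to compound 2, concerns a different place and a different kind of change, and so says nothing about the size or direction of the present one. With no guidance, the expectation is a step from compound 1 to compound 3 that stays close to the scatter, a number 4.2 percentage points higher from compound 1 to compound 3 (within the scatter), and compound 3 is estimated at 23%, within a range of 8% to 42%.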

Compound 3, a percentage reported as inhibition, at one concentration (the size of the read-out at that concentration, not a potency): 76.9%
The estimate for compound 3 lay 53.9 percentage points below the measured number; the whole stated range lies below it.
By their numbers in this assay, from the lowest: compound 1; then compound 2; then compound 3.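

In this assay, the group on the aromatic nitrogen proves to matter a great deal: with the rest of the molecule unchanged, cyclopentyl in place of isopropyl gives a number 58.1 percentage points higher from compound 1 to compound 3 (beyond the scatter). For the compounds shown here, the only earlier step, a number 22.9 percentage points higher from compound 1 to compound 2 (beyond the scatter), lay at the other end of the molecule and left isopropyl in place, so it gave no view of this position. The new step shows that going from the 3 carbons of isopropyl to the 5 carbons of a non-aromatic ring can shift the read-out by a large amount, although no information here explains why.

The compounds shown cannot separate the effect of the ring from that of the added carbons; a cyclobutyl or cyclohexyl ring, or an open pentyl chain, on the same nitrogen would help to tell these apart. From the compounds shown here alone, it also remains open whether the ethenyl group of compound 2 and the cyclopentyl group of compound 3 would add to each other in one molecule.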